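Chlorofuran series: phenyl variation at the ring carbon next to nitrogen

The source may report more compounds than this note shows. Statements on the series, on what has been measured and on what is new or still open speak of the compounds shown alone.

Measured so far:
compound 1 `Clc1ccc(-c2cc(-c3cccnc3)nc(-c3cccs3)c2)o1`: 25.8%
compound 2 `Clc1ccc(-c2cc(-c3ccco3)nc(-c3cccs3)c2)o1`: 16%
compound 3 `Clc1cccc(-c2cc(-c3ccc(Cl)o3)cc(-c3cccs3)n2)c1`: 42%

In an assay on isolated protein for inhibition of DNA topoisomerase 1 (Homo sapiens), tested at 100 uM (a higher number here means a stronger effect of the compound at the concentration tested, a lower number a weaker effect), compound 3 gives the highest of the three numbers; the step of a number 16.2 percentage points higher from compound 1 to compound 3 (beyond the scatter) and the step of a number 26 percentage points higher from compound 2 to compound 3 (beyond the scatter) both lie beyond the scatter, whereas the step of a number 9.8 percentage points lower from compound 1 to compound 2 (within the scatter) does not. Compound 4 `Cc1ccc(-c2cc(-c3ccc(Cl)o3)cc(-c3cccs3)n2)cc1` keeps the core of compound 3 and differs in one place: 4-methylphenyl in place of 3-chlorophenyl on an aromatic carbon. The change sits on the aromatic carbon next to the ring nitrogen, the same position varied in the two measured steps, but those steps exchange a heteroaryl group for 3-chlorophenyl, not one phenyl for another. Going by the values given here, no measured step shows what a 4-methylphenyl group does here; both steps toward 3-chlorophenyl were modest, so the carbocyclic ring at this position appears to carry part of the number for compound 3. The expected step of a number 6 percentage points lower from compound 3 to compound 4 (within the scatter) is therefore small, probably within the scatter, with a slight lean downward. Compound 4 is estimated at 36% in this assay, in the range 22% to 50%.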

Compound 4, a percentage reported as inhibition, at one concentration (the size of the read-out at that concentration, not a potency): 41.8%
For compound 4 the middle estimate is 5.8 percentage points below the measured one; low and high end bracket the measured number.
By their numbers in this assay, from the lowest: compounds 2 and 1 (each within the scatter of the next); then compounds 4 and 3 (each within the scatter of the next).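

In this assay the exchange of 3-chlorophenyl for 4-methylphenyl next to the ring nitrogen gives a number 0.2 percentage points lower from compound 3 to compound 4 (within the scatter), so the ring substituent can change in both identity and location without a readable difference, and the chlorine of this phenyl group is not needed to hold the number. The 4-methylphenyl group also stands clear of both heteroaryl groups, with a number 25.8 percentage points higher from compound 2 to compound 4 (beyond the scatter) and a number 16 percentage points higher from compound 1 to compound 4 (beyond the scatter), which adds a second carbocyclic example to the separation seen with compound 3. Nothing available explains these differences.

Open, going by these compounds, is whether an unsubstituted phenyl group, or a phenyl group bearing an amine or a carboxylic acid, would stay at this level. Also open, on these data alone, is how far these single-concentration read-outs reflect potency.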